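Moving a methoxy group: what to expect for compound 3

The compounds below may be only part of what the source reports. "The series", "measured", "known", "first", "only" and "open" are said of these compounds alone.

Measured in a functional assay on MOLT-4 cells (Homo sapiens) for antiproliferative activity, with a stated time of 48 h; a lower number here means a stronger inhibitor, a higher number a weaker inhibitor:
- compound 1 `C=C(Br)C(=O)Nc1ccc(/C=C/C(=O)c2ccc(C)cc2)cc1`: 1700 nM
- compound 2 `C=C(Br)C(=O)Nc1ccc(/C=C/C(=O)c2ccc(OC)cc2)cc1`: 1300 nM

Compound 2 stands level with compound 1 on these numbers. Within the data shown here, the only measured step, a 1.3-fold lower number from compound 1 to compound 2 (0.12 log units; within the scatter), is methoxy in place of methyl on an aromatic carbon, and it does not separate the two compounds.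

Compound 3 `C=C(Br)C(=O)Nc1ccc(/C=C/C(=O)c2cccc(OC)c2)cc1` has the same atoms as compound 2, joined differently: 3-methoxyphenyl in place of 4-methoxyphenyl on a carbonyl carbon. The aryl group stays on the carbonyl carbon, and only the name of the group changes, from 4-methoxyphenyl to 3-methoxyphenyl.

Among the measured compounds shown here, no measured step makes this exact change, so the data give no direct guide to it. For the measured compounds named here, the one step that bears on it at all is the change from compound 1 to compound 2, which alters a group on the same aryl ring and stayed within the scatter. Two compounds are thin support, but they give no reason to expect a step beyond the scatter in this assay. The expected change is small, and the estimate is a 1.2-fold higher number from compound 2 to compound 3 (0.06 log units; within the scatter). For compound 3 the estimated value is 1500 nM, with an expected range from 650 nM to 3500 nM.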

Compound 3, half-maximal inhibitory concentration: 850 nM
For compound 3 the middle estimate is 1.8-fold (0.25 log units) above the measured one, within the range that was stated.
By their numbers in this assay, from the lowest: compounds 3, 2 and 1 (each within the scatter of the next).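

In this assay, 3-methoxyphenyl in place of 4-methoxyphenyl on a carbonyl carbon gives a 1.5-fold lower number from compound 2 to compound 3 (0.18 log units; within the scatter), so this first change in how the methoxy group is attached to the aryl ring does not separate the two compounds. Set against the methyl-bearing compound, 3-methoxyphenyl in place of 4-methylphenyl gives a 2.0-fold lower number from compound 1 to compound 3 (0.30 log units; within the scatter), the largest step among the three compounds and still not one that separates the pair. No measurement shown offers an explanation for these numbers.

The three compounds leave open whether a different kind of group on this aryl ring, such as a hydroxyl, an amine or a carboxylic acid, would give a step beyond the scatter in this assay. They also leave open whether changes in the shared core outside this aryl group would shift the number further, since all the steps shown here concern a single place in the structure.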